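Pyridinyl carbamate on the difluoromethyl ether core

The source may report more compounds than this note shows. Statements on the series, on what has been measured and on what is new or still open speak of the compounds shown alone.

Compound 3 `Cc1cc(Nc2nc(Cl)cn([C@H](COC(=O)Nc3ccccc3)C3CC3)c2=O)c(C)nc1OC(F)F` gives 0.74 nM in an assay on frontal cortex for displacement of a labelled ligand from corticotropin-releasing factor receptor 1 (Rattus norvegicus), with a stated time of 2 h (on this read-out lower numbers stand for stronger inhibition and higher numbers for weaker inhibition), and holds the lowest number of the three measured. Its nearest neighbour is compound 1 `COc1nc(C)c(Nc2nc(Cl)cn([C@H](COC(=O)Nc3ccccc3)C3CC3)c2=O)cc1C`, which gives 1.5 nM; compound 2 `COc1nc(C)c(Nc2nc(Cl)cn([C@H](COC(=O)Nc3cccnc3)C3CC3)c2=O)cc1C` gives 10 nM and stands furthest from compound 3. Both measured steps change a single group: a 2.0-fold lower number from compound 1 to compound 3 (0.31 log units; beyond the scatter), and a 6.7-fold higher number from compound 1 to compound 2 (0.82 log units; beyond the scatter).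

Compound 4 `Cc1cc(Nc2nc(Cl)cn([C@H](COC(=O)Nc3cccnc3)C3CC3)c2=O)c(C)nc1OC(F)F` is the next member of the series. It differs from compound 3 in one place: pyridin-3-yl in place of phenyl on an amide-type nitrogen. For the measured compounds named here, only one measured step bears on this exchange, namely a 6.7-fold higher number from compound 1 to compound 2 (0.82 log units; beyond the scatter), where the same replacement on the same amide-type nitrogen was made on the core carrying methyl on the ring oxygen. Going by the values given here, no second pair tests the exchange on the difluoromethyl-bearing core, so whether its size carries over is unchecked; the step from compound 1 to compound 3 was itself modest and touched a different position. A step of about the same size and the same direction, upward, is therefore expected, a 6.8-fold higher number from compound 3 to compound 4 (0.83 log units; beyond the scatter). For compound 4 the estimate in this assay is 5 nM, with a range from 2 nM to 12 nM.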

Compound 4, half-maximal inhibitory concentration: 1.9 nM
Compound 4: middle estimate off by 2.6-fold (0.42 log units), on the high side; measured number outside the range, below it.
By their numbers in this assay, from the lowest: compound 3; then compounds 1 and 4 (each within the scatter of the next); then compound 2.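

Working notes on the carbamate position: on the core carrying difluoromethyl on the ring oxygen, pyridin-3-yl in place of phenyl on the amide-type nitrogen gives a 2.6-fold higher number from compound 3 to compound 4 (0.41 log units; beyond the scatter), so the upward direction seen on the core of compound 1 now holds on a second core, and the two step sizes cannot be told apart: the same change on two cores in this assay, a 6.7-fold higher number (0.82 log units; beyond the scatter) from compound 1 to compound 2 and a 2.6-fold higher number (0.41 log units; beyond the scatter) from compound 3 to compound 4, 2.6-fold (0.41 log units) apart, within the scatter of two such steps

The ether change can now also be read on the pyridin-3-yl carbamate, where difluoromethyl in place of methyl on the oxygen gives a 5.3-fold lower number from compound 2 to compound 4 (0.72 log units; beyond the scatter), the same downward direction as on the phenyl carbamate, again with no size difference that can be separated from scatter: the same change on two cores in this assay, a 2.0-fold lower number (0.31 log units; beyond the scatter) from compound 1 to compound 3 and a 5.3-fold lower number (0.72 log units; beyond the scatter) from compound 2 to compound 4, 2.6-fold (0.41 log units) apart, within the scatter of two such steps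

Across these four compounds in this assay, each change moves the number the same way on both cores, and none of the four goes against this.

Going by these compounds, how pyridin-4-yl or cyclohexyl on the amide-type nitrogen would read remains open, as does trifluoromethyl on the oxygen. For the compounds shown here, each change also rests on only two pairs, so whether the same directions hold on any further core is unknown.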